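A few compounds are considered here, and "the series" means these few. Any claim that something is new, unique, unknown or untested is made for them only; others in the source may bear on it.

The measured compounds are:
compound 1, `COc1cc(-c2cc(/C=C/C(=O)c3ccc(N)cc3)[nH]n2)cc(OC)c1OC`, with 470 nM;
compound 2, `COc1ccc(-c2cc(/C=C/C(=O)c3ccc(N)cc3)[nH]n2)cc1OC`, with 1280 nM;
compound 3, `COc1cc(C(=O)/C=C/c2cc(-c3cc(OC)c(OC)c(OC)c3)n[nH]2)cc(OC)c1OC`, with 310 nM.

All three were tested in a functional assay on RPMI-8226 cells (Homo sapiens) for inhibition, read by sulforhodamine B assay, with a stated time of 48 h; on this read-out higher numbers stand for weaker inhibition of growth and lower numbers for stronger inhibition of growth. Compound 3 gives the lowest number of the three, but its gap to compound 1 lies within the scatter, so no order between those two is claimed, whereas compound 2 stands beyond the scatter from both. The difference between the core of compound 1 and the core of compound 3 is not broken down here.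

Compound 1 and compound 2 differ in one place: hydrogen in place of methoxy on an aromatic carbon. This change produced a 2.7-fold higher number from compound 1 to compound 2 (0.44 log units; beyond the scatter), a modest weakening of growth inhibition.

Compound 4, `COc1ccc(-c2cc(/C=C/C(=O)c3cc(OC)c(OC)c(OC)c3)[nH]n2)cc1OC`, has not yet been measured in this assay. It is related to compound 3 by one change: hydrogen in place of methoxy on an aromatic carbon. The surroundings of the place read the same in both pairs, so this is the same change carried onto a different core, and only these two examples of it are present among the compounds shown.

Going by the values given here, because the one earlier example of this change gave a 2.7-fold higher number from compound 1 to compound 2 (0.44 log units; beyond the scatter), a step of similar size and direction is expected here, namely a 2.6-fold higher number from compound 3 to compound 4 (0.41 log units; beyond the scatter). Among the compounds with values here, with only a single precedent, the range is kept wide. Compound 4 is therefore estimated at 800 nM, with a range from 350 nM to 2000 nM.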

Compound 4, concentration for 50% growth inhibition: 290 nM
For compound 4 the middle estimate is 2.8-fold (0.44 log units) above the measured one; the measured number lies below the stated range.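

In this assay, hydrogen in place of methoxy on an aromatic carbon gives a 1.1-fold lower number from compound 3 to compound 4 (0.03 log units; within the scatter), so on this core the loss of the methoxy group leaves no readable difference in growth inhibition, unlike the modest weakening seen on the core of compound 1. The change therefore does not carry over from one core to the other with a fixed size in this series, even though the surroundings of the place read the same in both pairs, and the two examples stand apart by more than the scatter of two such steps: the same change on two cores in this assay, a 2.7-fold higher number (0.44 log units; beyond the scatter) from compound 1 to compound 2 and a 1.1-fold lower number (0.03 log units; within the scatter) from compound 3 to compound 4, 2.9-fold (0.46 log units) apart, beyond the scatter of two such steps This pair of examples shows only that the size of the step depends on the core it is made on; it does not show which part of the core decides this, why the two cores part, or which of the two results would be the more usual one on a further core.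

Going by these compounds, it remains open whether a hydroxyl group, an ethoxy group or a chlorine atom at this place would follow the pattern of one core or the other. On these data alone, it also remains open how the same change would read on a core carrying a carboxylic acid in place of the amine of compound 1.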